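The compounds below may be only part of what the source reports. "The series", "measured", "known", "first", "only" and "open" are said of these compounds alone.

Of the compounds shown here, three built on one shared core have been measured in an ADME assay on cells (Hepatocyte, Homo sapiens) for pharmacokinetics, read by LC-MS, with a stated time of 90 min, tested at 1 uM; a lower number here means slower removal, a higher number faster removal of the compound. Compound 1 `COc1ccc(Nc2c(NC(C)CCCCC(=O)NO)c(=O)c2=O)cc1` gives 7.1 uL/min. Compound 2 `CC(CCCCC(=O)NO)Nc1c(Nc2ccc(C(F)(F)F)cc2)c(=O)c1=O` carries a trifluoromethyl in place of the methoxy of compound 1, and compound 2 gives 21 uL/min; that single swap produced a 3.0-fold higher number from compound 1 to compound 2 (0.47 log units; beyond the scatter). Compound 3 `CC(C)(CCCCC(=O)NO)Nc1c(Nc2ccc(C(F)(F)F)cc2)c(=O)c1=O` carries a methyl in place of hydrogen on a saturated chain carbon bound to a nitrogen on an aromatic ring and two saturated chain carbons, and compound 3 gives 29 uL/min, so a 1.4-fold higher number from compound 2 to compound 3 (0.14 log units; within the scatter). Compound 3 therefore sits beyond the scatter above compound 1 but within the scatter of compound 2.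

Compound 4 `COc1ccc(Nc2c(NC(C)(C)CCCCC(=O)NO)c(=O)c2=O)cc1` has not yet been measured. It differs from compound 3 in one place: methoxy in place of trifluoromethyl on an aromatic carbon. Among the measured compounds shown here, this is the exact reverse of the swap between compound 1 and compound 2, the one step here that lay beyond the scatter, a 3.0-fold higher number from compound 1 to compound 2 (0.47 log units; beyond the scatter). The other step, a 1.4-fold higher number from compound 2 to compound 3 (0.14 log units; within the scatter), concerns a different part of the molecule and does not bear on this swap. A step of similar size in the opposite direction is therefore expected, with the number falling; the estimated step is a 2.9-fold lower number from compound 3 to compound 4 (0.46 log units; beyond the scatter). Compound 4 is expected to give about 10 uL/min, within a range from 5 uL/min to 20 uL/min.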

Compound 4, intrinsic clearance in a liver preparation (reported as CLH), per the amount of preparation that the assay uses in the Hepatocyte assay: 9.2 uL/min
The estimate for compound 4 lay 1.1-fold (0.04 log units) above the measured number; low and high end bracket the measured number.
By their numbers in the Hepatocyte assay, from the lowest: compounds 1 and 4 (each within the scatter of the next); then compounds 2 and 3 (each within the scatter of the next).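

The swap between methoxy and trifluoromethyl on this aromatic carbon now holds in both directions and on two cores, since in the Hepatocyte assay the change gives a 3.2-fold lower number from compound 3 to compound 4 (0.50 log units; beyond the scatter), which closely repeats the earlier step: the same change on two cores in the Hepatocyte assay, a 3.0-fold higher number (0.47 log units; beyond the scatter) from compound 1 to compound 2 and a 3.2-fold higher number (0.50 log units; beyond the scatter) from compound 4 to compound 3, 1.1-fold (0.03 log units) apart, within the scatter of two such steps. The added methyl on the saturated chain carbon also stays small in the methoxy series, with a 1.3-fold higher number from compound 1 to compound 4 (0.11 log units; within the scatter), so both trifluoromethyl and methoxy compounds now show a step within the scatter: the same change on two cores in the Hepatocyte assay, a 1.4-fold higher number (0.14 log units; within the scatter) from compound 2 to compound 3 and a 1.3-fold higher number (0.11 log units; within the scatter) from compound 1 to compound 4, 1.1-fold (0.03 log units) apart, within the scatter of two such steps. A second read-out appears for this pair, which differs only in the swap: in a physicochemical assay for solubility, read by HPLC, in phosphate buffer, with a stated time of 24 h, at pH 7.4, tested at 100 uM (on this read-out lower numbers stand for lower solubility and higher numbers for higher solubility), compound 3 gives 36000000 nM and compound 4 gives 99000000 nM, a 2.8-fold higher number from compound 3 to compound 4 (0.44 log units; beyond the scatter).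

With only methoxy and trifluoromethyl on this aromatic carbon, the compounds shown leave open where a group such as an amine, a nitrile or a carboxylic acid would fall in the Hepatocyte assay and in the physicochemical assay. They also cannot tell which part of the molecule the liver cells act on, or whether a longer chain in place of the present one would change the number.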